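The source may hold more compounds than are shown below. What is called first, only, known or untested is meant among the compounds shown, and "the series" means these compounds.

Working notes on the series.

Two compounds carry numbers or entries in an assay on isolated protein for inhibition of Indoleamine 2,3-dioxygenase 1 (Homo sapiens), read by spectrophotometry; on this read-out higher numbers stand for weaker inhibition and lower numbers for stronger inhibition. Compound 1, `O=C(Cc1ccncc1)c1cc2ccccc2[nH]1`, is recorded in this assay as "not active" (no number reported), with no number behind it. Compound 2, `O=C(Cc1cccnc1)c1cc2ccccc2[nH]1`, gives in this assay 65000 nM. That value is the only number shown for the series so far; the one further entry, compound 1, stands without a single number, so compound 2 is the sole reference point and no step between measured compounds can be stated.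

Compound 3, `O=C(Cc1cccnc1)c1cc2cc([N+](=O)[O-])ccc2[nH]1`, is the next member awaiting measurement in this assay. Relative to compound 2 the change is nitro in place of hydrogen on an aromatic carbon. Nothing in the measured pair bears on this change, so the expectation rests only on the reference value of compound 2.

The step expected from compound 2 to compound 3 in this assay is a 2.2-fold lower number from compound 2 to compound 3 (0.34 log units; beyond the scatter), read as a modest move toward stronger inhibition that may not exceed the scatter. For compound 3 the estimated value in this assay is 30000 nM, with a range from 5000 nM to 150000 nM.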

Compound 3, half-maximal inhibitory concentration: "not active" (no number reported)
No number was reported for compound 3, and the estimate cannot be compared.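

In this assay, among these compounds, compound 3 is recorded as "not active" (no number reported), so no step from compound 2 to compound 3 can be read. No supporting evidence bears on this result. The compounds shown leave open whether nitro in place of hydrogen changes inhibition relative to compound 2 at 65000 nM, and by how much.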